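Iodophenyl for chlorophenyl on a piperazine-linked xanthine-like core

This account rests on a few compounds, and the source may have more. Where it says the series, first, only, none or still open, it means among the compounds named here.

Measured so far:
- compound 1, `CCCn1c(=O)[nH]c2nc(-c3ccc(S(=O)(=O)N4CCN(c5cccc(Cl)c5)CC4)cc3)[nH]c2c1=O`: 0.342 nM
- compound 2, `CCCn1c(=O)c2[nH]c(-c3ccc(S(=O)(=O)N4CCN(c5ccc(Cl)cc5)CC4)cc3)nc2n(CC)c1=O`: 4.31 nM

Both compounds were tested in an assay on CHO cells for displacement of a labelled ligand from adenosine receptor A2b (Homo sapiens), read by scintillation counting, with a stated time of 75 min, in the presence of a further agent that is not named here; on this read-out lower numbers stand for stronger inhibition and higher numbers for weaker inhibition. Compound 1 has the lowest number of the two, and compound 2 stands at a number that is beyond the usual scatter above it. The two differ in more than one place, so their values alone cannot be tied to a single change.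

Compound 3, `CCCn1c(=O)[nH]c2nc(-c3ccc(S(=O)(=O)N4CCN(c5ccc(I)cc5)CC4)cc3)[nH]c2c1=O`, has not yet been measured. It differs from compound 1 in one place: 4-iodophenyl in place of 3-chlorophenyl on an amine nitrogen in a ring. The shared core of compound 1 and the sulfonyl-piperazine linker stay the same; only the aryl group on the ring nitrogen changes.

Within the data shown here, no measured pair shows this exact change, so the expectation rests on compound 1 alone. A modest rise in the number, at or only a little beyond the scatter, is expected, giving an estimated step of a 2.3-fold higher number from compound 1 to compound 3 (0.37 log units; beyond the scatter) in this assay. On that basis compound 3 is estimated at 0.8 nM in this assay, with a likely range from 0.2 nM to 3.5 nM.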

Compound 3, inhibition constant: 0.159 nM
The estimate for compound 3 lay 5.0-fold (0.70 log units) above the measured number, outside the stated range (below it).
By their numbers in this assay, from the lowest: compound 3; then compound 1; then compound 2.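

In this assay, placing 4-iodophenyl where 3-chlorophenyl stood on the amine nitrogen in a ring gives a 2.2-fold lower number from compound 1 to compound 3 (0.33 log units; beyond the scatter), a modest step. This position therefore accepts a different halogen at a different place on the phenyl ring, and inhibition is not lost; on this pair it becomes somewhat stronger, even though compound 1 already had a very low number. Nothing measured alongside these compounds explains the step.

The halogen and its place on the phenyl ring changed together, so this single step cannot show how much each contributed; 3-iodophenyl on the same core would help separate the two, since it would share its halogen with compound 3 and its place with compound 1. From the compounds shown here alone, it also remains open whether this position needs a halogen at all, which a plain phenyl group or a phenyl group carrying a methoxy group or a carboxylic acid could test.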